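Adding ethyl to the ring nitrogen of compound 1

The source may hold more compounds than are shown below. What is called first, only, known or untested is meant among the compounds shown, and "the series" means these compounds.

In a functional assay on NCI-H1650 cells (Homo sapiens) for cytotoxicity, read by MTT assay, with a stated time of 72 h (on this read-out lower numbers stand for stronger inhibition and higher numbers for weaker inhibition), compound 1 `COc1cc(/C=C2\CNC/C(=C\c3cc(OC)c(OC)c(OC)c3)C2=O)cc(OC)c1OC` gives 4200 nM and compound 2 `CCCN1C/C(=C\c2ccc(OC)c(OC)c2)C(=O)/C(=C/c2ccc(OC)c(OC)c2)C1` gives 16000 nM in the same test, so compound 1 holds the lower, stronger number of the two, by a margin beyond the usual scatter. Compound 3 `CCN1C/C(=C\c2cc(OC)c(OC)c(OC)c2)C(=O)/C(=C/c2cc(OC)c(OC)c(OC)c2)C1` differs from compound 1 in one place (ethyl in place of hydrogen on an amine nitrogen in a ring): ethyl in place of hydrogen on an amine nitrogen in a ring. Within the data shown here, no measured pair shows this change alone. Compound 2 also carries a carbon chain on that nitrogen and gives 16000 nM in this assay but differs in its other groups too, so it offers only a weak hint. The step expected in this assay is small, toward a higher number, and possibly within the scatter. Going by these compounds, as a step, the estimate is a 1.4-fold higher number from compound 1 to compound 3 (0.15 log units; within the scatter) and remains untested. For compound 3 the estimate is 6000 nM with an expected range from 2000 nM to 16000 nM once it is measured.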

Compound 3, half-maximal inhibitory concentration: 8200 nM
Beside the measured number, compound 3's estimate is 1.4-fold (0.14 log units) below it, and the stated range covers the measured number.
By their numbers in this assay, from the lowest: compounds 1, 3 and 2 (each within the scatter of the next, the first and the last beyond it).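

Among these compounds, the ring nitrogen can now be read on its own for the first time. In this assay ethyl in place of hydrogen on an amine nitrogen in a ring gives a step within the usual scatter (a 2.0-fold higher number from compound 1 to compound 3 (0.29 log units; within the scatter)), so compound 1 and compound 3 cannot be told apart, and the hydrogen on this nitrogen is not needed to hold the activity at this level. No supporting measurement accompanies this result, so the pair stays a plain observation without an explanation.

A single ethyl step says little about what else this nitrogen accepts, such as a longer chain, a benzyl group or an acetyl group. Going by these compounds, whether ethyl would behave the same way with other groups on the rest of the core also stays open.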